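Swapping the Ester Side Chain of Compound 1

This account rests on a few compounds, and the source may have more. Where it says the series, first, only, none or still open, it means among the compounds named here.

Measured so far:
compound 1 `CC(=O)OCCO[C@H](CC=C(C)C)C1=CC(=O)c2c(O)ccc(O)c2C1=O`: 15500 nM
compound 2 `CC[C@@](C)(O)CC(=O)O[C@H](CC=C(C)C)C1=CC(=O)c2c(O)ccc(O)c2C1=O`: 12700 nM
compound 3 `CC(C)=CC[C@@H](OC(=O)CC(C)(O)c1ccccc1)C1=CC(=O)c2c(O)ccc(O)c2C1=O`: > 100000 nM

In a functional assay on DU-145 cells (Homo sapiens) for cytotoxicity, read by MTT assay (on this read-out higher numbers stand for weaker inhibition and lower numbers for stronger inhibition), compound 1 gives the higher of the two plain numbers, with compound 2 nearest: a 1.2-fold lower number from compound 1 to compound 2 (0.09 log units; within the scatter). For compound 3 the value is a limit of the assay, not a number (the limit of > 100000 nM in this assay, at which 1 of the 3 values shown sits). Compound 4 `CC(C)=CC[C@@H](OC(=O)C1CCCOC1)C1=CC(=O)c2c(O)ccc(O)c2C1=O` differs from compound 1 by the change ((oxan-3-yl)carbonyl in place of 2-acetoxyethyl on an oxygen on a saturated carbon). This step resembles the one in which one ester group replaced another and the result stayed within the scatter; the sharp loss seen as an at least 7.8-fold higher number from compound 2 to compound 3 (0.89 log units; beyond the scatter) followed a phenyl-bearing group, which compound 4 does not carry. No step beyond the scatter is therefore expected, a 1.0-fold lower number from compound 1 to compound 4 (0.01 log units; within the scatter). Compound 4 is expected to give 15000 nM (range 6000 nM to 50000 nM).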

Compound 4, half-maximal inhibitory concentration: 29700 nM
For compound 4 the middle estimate is 2.0-fold (0.30 log units) below the measured one; the range from low to high includes it.
By their numbers in this assay, from the lowest: compounds 2, 1 and 4 (each within the scatter of the next, the first and the last beyond it). At a limit, above all of these: compound 3.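

A non-aromatic ring on this oxygen leaves measurable activity, with an at least 3.3-fold lower number from compound 3 to compound 4 (0.52 log units; beyond the scatter) once oxan-3-yl takes the place of the phenyl-bearing group. The value for compound 3 is a limit of the assay, not a number. The ring costs little against the open chains, with a 1.9-fold higher number from compound 1 to compound 4 (0.28 log units; within the scatter) and a 2.3-fold higher number from compound 2 to compound 4 (0.37 log units; beyond the scatter) as the only step beyond the scatter among these two.

Going by these compounds, whether an amine or a carboxylic acid on this ester would keep the activity remains open. So does whether a longer chain would match the 2-hydroxy-2-methylbutyl group.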